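A few compounds are considered here, and "the series" means these few. Any claim that something is new, unique, unknown or untested is made for them only; others in the source may bear on it.

Among the measured compounds shown here, in a functional assay on SK-OV-3 cells (Homo sapiens) for inhibition, read by MTT assay (a lower number here means a stronger inhibitor, a higher number a weaker inhibitor), only two compounds have numbers so far. Compound 1 `COc1ccc(/C=C2\c3cc(OC)c(OC)c(OC)c3CC[C@@H]2O)cc1O` gives 1060 nM, and compound 2 `COc1ccc(/C=C2\c3cc(OC)c(OC)c(OC)c3CC[C@H]2O)cc1N` gives 1870 nM. These two values lie within the usual scatter of each other, so the data cannot separate compound 2 from compound 1.

Compound 3 `COc1ccc(/C=C2\c3cc(OC)c(OC)c(OC)c3CC[C@H]2O)cc1O` has not yet been measured. It differs from compound 2 by a single swap, hydroxy in place of amino on an aromatic carbon, ortho to a methoxy group. For the measured compounds named here, no measured pair shows this swap on its own, so the expectation rests on very little. Compound 1, which also carries a 3-hydroxy-4-methoxyphenyl, gives 1060 nM, so no change beyond the scatter is expected in this assay. The expected 1.4-fold lower number from compound 2 to compound 3 (0.16 log units; within the scatter) stays within the scatter. Compound 3 is expected at about 1300 nM, with an estimated range of 450 nM to 3800 nM.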

Compound 3, half-maximal inhibitory concentration: 1590 nM
Compound 3: middle estimate off by 1.2-fold (0.09 log units), on the low side; the range from low to high includes it.
By their numbers in this assay, from the lowest: compounds 1, 3 and 2 (each within the scatter of the next).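

In this assay, hydroxy in place of amino on this aromatic carbon, ortho to a methoxy group, gives a 1.2-fold lower number from compound 2 to compound 3 (0.07 log units; within the scatter), so the data do not separate these two groups at this position. Changing only the stereocentre at the saturated ring carbon gives a 1.5-fold higher number from compound 1 to compound 3 (0.18 log units; within the scatter), so the two configurations cannot be told apart here either. Earlier, the two measured compounds differed in both places at once, and each change can now be read alone, the second through one clean pair: the fact that compounds 1 and 3 differ only in the configuration as drawn.

Still open, from the compounds shown here alone, is whether a different group at this aromatic position, such as a carboxylic acid or a longer alkoxy chain, would shift the number beyond the scatter. Also open, going by these compounds, is whether the amino group would give a similar number with the stereocentre drawn S.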